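The source may hold more compounds than are shown below. What is called first, only, known or untested is meant among the compounds shown, and "the series" means these compounds.

Measured in a functional assay on HT-29 cells (Homo sapiens) for cytotoxicity, read by XTT assay, with a stated time of 72 h; on this read-out lower numbers stand for stronger inhibition and higher numbers for weaker inhibition:
- compound 1 `COc1cc(C(O)c2ccc3c(ccn3C)c2)cc(OC)c1OC`: > 1000 nM
- compound 2 `CCn1ccc2cc(C(O)c3cc(OC)c(OC)c(OC)c3)ccc21`: > 1000 nM

Compound 1 stands at > 1000 nM, which is a limit of the assay and not a number. Compound 2 gives > 1000 nM, which is also a limit. The whole record so far is therefore (the limit of > 1000 nM in this assay, at which 2 of the 2 values shown sit).

The next compound is compound 3 `COc1cc(C(OC(C)=O)c2ccc3c(ccn3C)c2)cc(OC)c1OC`. It departs from compound 1 by one change, hydroxy to acetoxy: acetyl in place of hydrogen on an oxygen on a saturated carbon.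

Going by the values given here, the only measured step is a step that the two limits leave unreadable from compound 1 to compound 2. It lies at a different place in the molecule, and it offers no size to carry over to a change on the oxygen. Among the compounds with values here, no step speaks to this change, so no direction can be argued from the data. The expectation rests on the value of compound 1, > 1000 nM, and a reading at the same limit in this assay is considered the most likely result. The estimated step is a step that the limit leaves unreadable from compound 1 to compound 3, with no real shift expected. Compound 3 is expected at 2000 nM, with an estimated range of 400 nM to 10000 nM.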

Compound 3, half-maximal inhibitory concentration: 260 nM
The estimate for compound 3 lay 7.7-fold (0.89 log units) above the measured number; measured number below the stated range.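

In this assay, going by these compounds alone, the oxygen on the saturated carbon is the first place where a change gives a readable step: acetyl in place of hydrogen, hydroxy to acetoxy, gives an at least 3.8-fold lower number from compound 1 to compound 3 (0.58 log units; beyond the scatter). Compound 3, which has no hydrogen left on that oxygen, gives 260 nM, so a free hydroxy at this place is not needed for a number inside the range of this assay. The step on the saturated chain carbon bound to the aromatic nitrogen cannot be read, which leaves this as the only size in the series, with most of the record still a limit: the limit of > 1000 nM in this assay, at which 2 of the 3 values shown sit.

The compounds shown do not tell whether this step belongs to acetyl alone or extends to other groups on the same oxygen, such as a longer acyl chain like propanoyl, a benzoyl, a methyl ether or a carbamate, or to an amine in place of the oxygen. As far as these compounds go, whether acetoxy gives a step of similar size on the core of compound 2, with its ethyl group, also stays open.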